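The compounds below may be only part of what the source reports. "The series", "measured", "known", "first", "only" and "open" are said of these compounds alone.

This piece follows one change made to compound 1 `CCCNc1nc(N)c2nc(O)n(Cc3ccccc3)c2n1`. In a functional assay (spleen, spleen) for activation, with Mus musculus as the target (on this read-out higher numbers stand for an effect only at larger amounts of compound and lower numbers for an effect already at smaller amounts), compound 1 gives 0.1 uM, the lowest of the two numbers shown. Compound 3 `Nc1ncnc2c1nc(O)n2Cc1cccc2ccccc12` comes nearest with 10 uM, a gap well beyond the usual scatter. Compound 2 `Cc1nc2c(N)ncnc2n1Cc1ccccc1` gives > 10 uM, which is the limit of > 10 uM in this assay, at which 1 of the 3 values shown sits, and not a number. Compound 4 `COc1nc(N)c2nc(O)n(Cc3ccccc3)c2n1` has not yet been measured; it differs from compound 1 by methoxy in place of propylamino on an aromatic carbon. Among the measured compounds shown here, no pair of measured compounds differing in one place exists here, so the size of this step has no direct precedent. A modestly weaker result is expected, a step of a 3.0-fold higher number from compound 1 to compound 4 (0.48 log units; beyond the scatter). Compound 4 is therefore estimated at 0.3 uM in this assay, within 0.05 uM to 3 uM.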

Compound 4, minimum effective concentration: 0.1 uM
For compound 4 the middle estimate is 3.0-fold (0.48 log units) above the measured one; the measured number falls inside the stated range.
By their numbers in this assay, from the lowest: compounds 1 and 4 (each within the scatter of the next); then compound 3.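

Among the compounds shown here, putting methoxy in place of propylamino on this aromatic carbon gives no change at the digits printed from compound 1 to compound 4 (within the scatter) in this assay, the first comparison here between compounds that differ in one place. At this position, a group with 2 heavy atoms and 0 hydrogen-bond donors therefore reads the same as one with 4 heavy atoms and 1 hydrogen-bond donor. Nothing shown accounts for this match. On these data alone, whether a butylamino chain, a plain amine or a carboxylic acid on this carbon would also read the same remains open.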